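A few compounds are considered here, and "the series" means these few. Any claim that something is new, unique, unknown or untested is made for them only; others in the source may bear on it.

Compound 1, `Nc1nccnc1C(=O)NN1C(=O)CSC1c1ccccc1`: in an ADME assay on MCF7 cells (Homo sapiens) for cytotoxicity, read by MTT assay, with a stated time of 4 days (on this read-out higher numbers stand for weaker inhibition and lower numbers for stronger inhibition), compound 1 gives 81.3 ug/mL.
Compound 2, `CCOc1cc([C@@H]2SCC(=O)N2NC(=O)c2cnc(C)cn2)ccc1O`: in this assay compound 2 gives only a limit, > 100 ug/mL.

On the numbers shown, compound 2 stands at the edge of what this assay can report: its value is a limit, not a measured number, as the evidence makes plain (the limit of > 100 ug/mL in this assay, at which 1 of the 2 values shown sits). Compound 1, by contrast, gives an actual reading within the range of this assay. For the measured compounds named here, no step between these two compounds is set out here, and the two structures differ in several places, so the two values can only be noted side by side.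

Compound 3, `COc1cc([C@@H]2SCC(=O)N2NC(=O)c2cnc(C)cn2)ccc1O`, is not yet measured. It differs from compound 2 in one place: hydrogen in place of methyl on a saturated chain carbon bound to an oxygen on an aromatic ring; in words, hydrogen in place of methyl on a saturated chain carbon bound to an oxygen on an aromatic ring, so that an ethoxy becomes a methoxy. This is a small change, and nothing among the compounds shown speaks for a shift beyond the usual scatter in either direction. Compound 3 is therefore expected to sit at about 110 ug/mL, within a range of 50 ug/mL to 250 ug/mL, and the expected step from the limit of compound 2 is a step that the limit leaves unreadable from compound 2 to compound 3, with a real chance that this assay again reports only a limit.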

Compound 3, half-maximal inhibitory concentration: 70.2 ug/mL
For compound 3 the middle estimate is 1.6-fold (0.20 log units) above the measured one, and the stated range covers the measured number.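

For the compounds shown here, with the ethoxy shortened to a methoxy, this position gives a real reading for the first time: in this assay compound 3 gives 70.2 ug/mL, a number that can serve as a fixed point for later comparisons. Replacing the methyl with hydrogen, on a saturated chain carbon bound to an oxygen on an aromatic ring, removes a single carbon and gives an at least 1.4-fold lower number from compound 2 to compound 3 (0.15 log units; that floor lies within the scatter); this figure is only the smallest step the data allow, so the true step may be as small as the usual scatter or may be larger. The full size of the step stays unknown because one end of it is a limit and not a number: the limit of > 100 ug/mL in this assay, at which 1 of the 3 values shown sits.

With only a methoxy and an ethoxy shown at this place, two groups cannot establish a trend with chain length. From the compounds shown here alone, whether a longer chain such as propoxy, or a bare hydroxyl in place of the methoxy, would give a lower or a higher number in this assay remains open.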